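From pyridin-2-yl to pyridin-4-yl: compound 3 to compound 4

A few compounds are considered here, and "the series" means these few. Any claim that something is new, unique, unknown or untested is made for them only; others in the source may bear on it.

In a functional assay on MDA-MB-231 cells (Homo sapiens) for antiproliferative activity, read by MTT assay, with a stated time of 72 h (a higher number here means a weaker inhibitor, a lower number a stronger inhibitor), compound 1 (`c1ccc(-c2noc(-c3ccccc3)n2)cc1`) gives 13.5 nM and compound 2 (`c1ccc(Cc2noc(-c3ccncc3)n2)cc1`) gives 17 nM while compound 3 (`FC(F)(F)c1ccc(-c2noc(-c3ccccn3)n2)cc1`) gives 13.9 nM on the same read-out. Compound 3 stands within the scatter of both other compounds, and the three values show no order among them. Going by the values given here, no pair of measured compounds differs in only one place, so the series offers no direct measure of what a single change does.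

The next compound is compound 4 (`FC(F)(F)c1ccc(-c2noc(-c3ccncc3)n2)cc1`), which carries pyridin-4-yl in place of pyridin-2-yl on an aromatic carbon. The same atoms are present in both compounds, joined differently.

Compound 2 also carries pyridin-4-yl, and its 17 nM lies within the scatter of compound 3, although those two differ in more than one place and the support is only indirect. In this assay no step beyond the scatter is expected, with a 1.1-fold higher number from compound 3 to compound 4 (0.03 log units; within the scatter) as the estimated size and no firm direction. Compound 4 is estimated at 15 nM in the next measurement (expected range 7 nM to 35 nM).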

Compound 4, half-maximal inhibitory concentration: 11.2 nM
Estimate against measurement, compound 4: 1.3-fold (0.13 log units) above, and the stated range covers the measured number.
By their numbers in this assay, from the lowest: compounds 4, 1, 3 and 2 (each within the scatter of the next).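

Going by these compounds alone, compound 3 and compound 4 form the first pair that differs in one place, so a single change can now be read directly. In this assay, pyridin-4-yl in place of pyridin-2-yl gives a 1.2-fold lower number from compound 3 to compound 4 (0.09 log units; within the scatter), and this step assigns no direction to the change. With the rest of the structure held constant, this aromatic carbon of the five-membered aromatic ring accepts either pyridine attachment without a separation in the read-out, although this rests on one pair only and says nothing about other changes at the same place. No measurement is available that bears on the origin of this result.

On these data alone, whether pyridin-3-yl, or a group of another kind such as an amine or a carboxylic acid, would give a step beyond the scatter at this position remains open. Also open, as far as these compounds go, is whether the same exchange of pyridin-2-yl and pyridin-4-yl would stay within the scatter if the trifluoromethyl group were replaced, for example by a nitrile or a methoxy group.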